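Fluorophenoxy in place of dichlorophenylsulfanyl on the shared core

The compounds below may be only part of what the source reports. "The series", "measured", "known", "first", "only" and "open" are said of these compounds alone.

Compound 2 `Nc1cc(N)c2nc(-c3ccccc3)c(Sc3ccc(Cl)c(Cl)c3)nc2c1` stands only at a limit: in a functional assay on SK-MEL-28 cells (Homo sapiens) for inhibition, read by sulforhodamine B assay, with a stated time of 48 h (a lower number here means that less compound is tolerated, a higher number that more compound is tolerated), compound 2 gives < 100000 nM, which is a limit of the assay and not a number. Compound 1 `Nc1cc(N)c2nc(-c3ccccc3)c(NCc3ccc(F)cc3)nc2c1` carries a (4-fluorobenzyl)amino group at the same place, and in this assay compound 1 gives 7410 nM. The step that the limit leaves unreadable from compound 1 to compound 2 cannot be read because one end of it sits at the limit of < 100000 nM in this assay, at which 1 of the 2 values shown sits.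

Compound 3 `Nc1cc(N)c2nc(-c3ccccc3)c(Oc3ccc(F)cc3)nc2c1` is not yet measured. Its change from compound 2 is 4-fluorophenoxy in place of (3,4-dichlorophenyl)sulfanyl on an aromatic carbon. No measured step bears on it with a readable size: the only step shown, from compound 1 to compound 2, is unreadable because of the limit of < 100000 nM in this assay, at which 1 of the 2 values shown sits. Among the measured compounds shown here, the 4-fluorophenyl piece of compound 3 matches that of compound 1 more closely than the dichlorophenyl piece of compound 2 does, and compound 1 supplies the one number in the set, 7410 nM. On that basis the step that the limit leaves unreadable from compound 2 to compound 3 is expected to lean toward the value of compound 1, its direction not fixed by the limit. For compound 3 the estimate in this assay is 15000 nM, with a range from 4000 nM to 60000 nM, and a fair chance that only a limit is reported.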

Compound 3, concentration lethal to 50% of the cells: < 100000 nM
Compound 3: no number, only a limit; the forecaster's own chance of this, stated with the estimate: 30%; the middle value does not contradict the limit.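

In this assay, among the compounds shown here, compound 3 gives < 100000 nM, which is a limit and not a number, and no step from compound 1 or compound 2 to compound 3 can be read because of it: the limit of < 100000 nM in this assay, at which 2 of the 3 values shown sit.

Compound 1, compound 2 and compound 3 leave open how the 4-fluorophenoxy and (3,4-dichlorophenyl)sulfanyl groups on the shared core compare with each other or with the (4-fluorobenzyl)amino group.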